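This account rests on a few compounds, and the source may have more. Where it says the series, first, only, none or still open, it means among the compounds named here.

Of the compounds shown here, three built on a shared core have been tested in an ADME assay on MRC5 cells (Homo sapiens) for inhibition, with a stated time of 72 h; a lower number here means that less compound is needed, a higher number that more compound is needed for the effect. Compound 1 `COc1cccc(OC)c1C(=O)Nc1c[nH]nc1C(=O)Nc1ccncc1` reaches only a limit of the assay there, > 50000 nM, so for compound 1 no number is known, just that limit. Compound 2 `CO[C@H]1CC[C@H](NC(=O)c2n[nH]cc2NC(=O)c2ccc(OC(F)F)cc2)CC1` gives 2500 nM in this assay. Compound 3 `CO[C@H]1CC[C@H](NC(=O)c2n[nH]cc2NC(=O)c2cc3ccccc3o2)CC1` gives 800 nM in this assay. Compounds 2 and 3 carry a different amide on the core than compound 1, so their values say nothing about where compound 1 would fall if it could be resolved; what is known of compound 1 is the limit of > 50000 nM in this assay, at which 1 of the 3 values shown sits.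

Compound 4 `COC(=O)c1n[nH]cc1NC(=O)c1c(OC)cccc1OC` has not yet been measured in this assay. It differs from compound 1 by methoxy in place of (pyridin-4-yl)amino on a carbonyl carbon. Among the compounds with values here, because compound 1 stands at the limit of > 50000 nM in this assay, at which 1 of the 3 values shown sits, no measured step starts from it, and the change is expected to move the value in this assay by no more than the scatter, in no clear direction. Compound 4 is expected to give about 70000 nM, within a range from 20000 nM to 250000 nM. The expected step is a step that the limit leaves unreadable from compound 1 to compound 4, and a limit rather than a number is expected again.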

Compound 4, half-maximal effective concentration: > 50000 nM
Compound 4 gave a limit, no number (the forecaster's own chance of this, stated with the estimate: 75%); the middle value lies beyond the limit too.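

Compound 1 and compound 4 both stand at a limit of the assay rather than at a number, so no step can be read between them: the limit of > 50000 nM in this assay, at which 2 of the 4 values shown sit.

The compounds shown leave open how far methoxy in place of (pyridin-4-yl)amino on a carbonyl carbon moves the value in this assay.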